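A few compounds are considered here, and "the series" means these few. Any claim that something is new, unique, unknown or untested is made for them only; others in the source may bear on it.

In a functional assay on AGS cells (Homo sapiens) for inhibition, read by reporter gene assay (a lower number here means a stronger inhibitor, a higher number a weaker inhibitor), compound 2, `CC(=O)c1ccc(OCC(=O)Nc2cccc(C(=O)O)c2)cc1`, stands at > 30000 nM, which is a limit of the assay and not a number. Compound 1, `O=C(COc1ccccc1)Nc1cccc(C(=O)O)c1`, gives > 30000 nM, also a limit. Compound 3, `O=C(COc1ccc(F)cc1)Nc1cccc(C(=O)O)c1`, gives > 30000 nM, again a limit. All the measurements in the series therefore sit at one place: the limit of > 30000 nM in this assay, at which 3 of the 3 values shown sit.

The change under study leads to compound 4, `O=C(COc1ccc(Cl)cc1)Nc1cccc(C(=O)O)c1`, with chloro in place of acetyl on an aromatic carbon. The closest measured parallel is a step that the two limits leave unreadable from compound 2 to compound 3, where fluoro takes the place of acetyl on an aromatic carbon. The other two measured steps are a step that the two limits leave unreadable from compound 1 to compound 2 and a step that the two limits leave unreadable from compound 1 to compound 3, with acetyl and fluoro each in place of hydrogen. None of the three has a readable size, so they offer no measured effect to carry over. With no sign of a change among these close relatives, no step beyond the scatter is expected in this assay, and no direction can be assigned. The expected step is a number no higher from compound 2 to compound 4 (the limit leaves the size open). A report of compound 4 at the same limit is the likeliest outcome. As a number, the estimate for compound 4 is 30000 nM, with an expected range from 12000 nM to 60000 nM.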

Compound 4, half-maximal inhibitory concentration: 10000 nM
For compound 4 the middle estimate is 3.0-fold (0.48 log units) above the measured one; the whole stated range lies above it.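

In this assay, the group on the aromatic carbon para to a large group now has a readable effect, with chloro giving an at least 3.0-fold lower number from compound 2 to compound 4 (0.47 log units; beyond the scatter), an at least 3.0-fold lower number from compound 3 to compound 4 (0.47 log units; beyond the scatter) and an at least 3.0-fold lower number from compound 1 to compound 4 (0.47 log units; beyond the scatter). Going by these compounds alone, compound 4 is the only compound to give a number and not a limit: the limit of > 30000 nM in this assay, at which 3 of the 4 values shown sit. The steps among compound 1, compound 2 and compound 3 cannot be read, so this place on the ring shows its first sign of sensitivity to the group it carries, and each step to compound 4 fixes only a smallest size.

Open, going by these compounds, is whether bromo, methyl or trifluoromethyl at this place would match chloro or go further, as the finding rests on compound 4 alone. Also open, on these data alone, is how the series responds when the carboxylic acid of the shared core gives way to an ester or an amide, or when a longer chain replaces the link to the ether oxygen.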